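Removal of the fluoro group from the pendant aryl ring

The source may hold more compounds than are shown below. What is called first, only, known or untested is meant among the compounds shown, and "the series" means these compounds.

Measured so far:
Compound 1 `COc1cc(OC)cc(-n2c(-c3ccccc3)nc(C)c2C)c1` gives 39.1%.
Compound 2 `COc1ccc(-n2c(-c3ccc(F)cc3)nc(C)c2C)cc1` gives 48.3%.

Both numbers come from a functional assay, read by spectrophotometry, with a stated time of 60 min, tested at 20 uM; on this read-out lower numbers stand for a weaker effect and higher numbers for a stronger effect at the one concentration tested. Compound 2 stands at one end of the two numbers measured, and compound 1 is its nearest neighbour; the two values lie within the usual scatter of each other, so neither compound can be set apart from the other on these data. Going by the values given here, compound 1 and compound 2 differ in more than one place, so no single step between them can be read.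

The next compound to be measured is compound 3 `COc1ccc(-n2c(-c3ccccc3)nc(C)c2C)cc1`. It follows from compound 2 by one change, (hydrogen in place of fluoro on an aromatic carbon).

Among the compounds with values here, no step between measured compounds covers this change, so its size is not known from the present numbers. The expected step from compound 2 to compound 3 in this assay is a number 4.3 percentage points lower from compound 2 to compound 3 (within the scatter), that is, none beyond the scatter. Compound 3 is estimated to give 44%, within a range from 28% to 60%.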

Compound 3, a percentage reported as activity, at one concentration (the size of the read-out at that concentration, not a potency): 40.2%
For compound 3 the middle estimate is 3.8 percentage points above the measured one; measured number inside the range.
By their numbers in this assay, from the lowest: compounds 1, 3 and 2 (each within the scatter of the next).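

In this assay, going by these compounds alone, the change from 4-fluorophenyl to phenyl provides the first single-place step: a number 8.1 percentage points lower from compound 2 to compound 3 (within the scatter). On this one step, fluoro and hydrogen on this aromatic carbon, para to a large group, cannot be told apart, so the fluoro group is not shown to be needed for the effect seen at the one concentration tested. No supporting measurement bears on this result, so it gives no explanation for the step or for the absence of a separation between the two compounds.

The compounds shown cover only fluoro and hydrogen at this carbon, so it remains open whether an amine, a carboxylic acid or a longer chain such as butoxy there would give a step beyond the scatter. It also remains open whether the same exchange on the pendant aryl ring would read alike with the other substitution on the opposite aryl ring seen in compound 1, and a single-concentration read-out gives no potency for any of these compounds.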